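A few compounds are considered here, and "the series" means these few. Any claim that something is new, unique, unknown or untested is made for them only; others in the source may bear on it.

Compound 1 `Cc1cc(OCc2c(-c3cc[nH]c(=O)c3Cl)noc2C(C)C)ccc1-c1ccc2c(C(=O)O)cn(C)c2c1`: 5000 nM
Compound 2 `COc1ccccc1-c1noc(C(C)C)c1COc1ccc(/C=C/c2cccc(C(=O)O)c2)c(Cl)c1`: 10000 nM
Compound 3 `Cc1cc(OCc2c(-c3c(Cl)ccc(=O)n3C)noc2C(C)C)ccc1-c1ccc2c(C(=O)O)cn(C)c2c1`: 4000 nM

In a functional assay for agonist activity at Bile acid receptor (Homo sapiens), read by a luciferase reporter (a lower number here means that less compound is needed, a higher number that more compound is needed for the effect), compound 3 gives the lowest of the three numbers. The step of a 1.3-fold lower number from compound 1 to compound 3 (0.10 log units; within the scatter) lies within the scatter, so the two cannot be told apart. Compound 2 gives a higher number, and that difference lies beyond the scatter.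

Compound 4 `COc1ccc(Cl)c(-c2noc(C(C)C)c2COc2ccc(-c3ccc4c(C(=O)O)cn(C)c4c3)c(C)c2)n1` is built from the same atoms as compound 3, joined differently: a group of 9 heavy atoms (6 carbon, 1 nitrogen, 1 oxygen, 1 chlorine; one six-membered aromatic ring with 1 hetero atom) in place of a group of 9 heavy atoms (6 carbon, 1 nitrogen, 1 oxygen, 1 chlorine; one six-membered aromatic ring with 1 hetero atom), on an aromatic carbon. Going by the values given here, the only measured step that bears on this is the exchange of one ring group for another at the same place, a 1.3-fold lower number from compound 1 to compound 3 (0.10 log units; within the scatter), which stayed within the scatter. A step of similar size is therefore expected, no change at the digits printed from compound 3 to compound 4 (within the scatter), with no clear direction. Compound 4 is estimated at 4000 nM, within a range from 1500 nM to 10000 nM.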

Compound 4, half-maximal effective concentration: 2000 nM
Beside the measured number, compound 4's estimate is 2.0-fold (0.30 log units) above it; measured number inside the range.
By their numbers in this assay, from the lowest: compounds 4, 3, 1 and 2 (each within the scatter of the next, the first and the last beyond it).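

In this assay, the 3-chloro-6-methoxypyridin-2-yl group on the five-membered ring, with the same atoms joined differently, gives a 2.0-fold lower number from compound 3 to compound 4 (0.30 log units; within the scatter), so rearranging these atoms produces no change that can be told apart. Going by these compounds alone, the same group, measured against the smaller group at this place, gives a 2.5-fold lower number from compound 1 to compound 4 (0.40 log units; beyond the scatter), the first step beyond the scatter at this position, though a modest one. Nothing measured here gives a reason for either step. The compounds shown leave open how an amine in place of the methoxy group would read at this place.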